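Swapping an oxadiazole for ethoxy in a cytotoxicity series

The source may report more compounds than this note shows. Statements on the series, on what has been measured and on what is new or still open speak of the compounds shown alone.

Compound 2 `Cc1nnc(-c2cccc(-c3ccc(C(=O)N(Cc4cccc(OCCCCCC(=O)O)c4)C(C)C)cc3)c2)o1` is the starting point. In an ADME assay on Raji cells (Homo sapiens) for cytotoxicity, read by CellTiter-Glo and resazurin assay, with a stated time of 72 h (a lower number here means that less compound is needed, a higher number that more compound is needed for the effect), compound 2 gives > 26000 nM, which is a limit of the assay rather than a number. Compound 1 `CC(C)N(Cc1cccc(OCCCCCC(=O)O)c1)C(=O)c1ccc(-c2cccc(N(C)C)c2)cc1` differs from compound 2 in one place. In this assay compound 1 gives > 26000 nM, again a limit rather than a number. The step that the two limits leave unreadable from compound 1 to compound 2 therefore cannot be read in size or direction, since both compounds sit at the limit of > 26000 nM in this assay, at which 2 of the 2 values shown sit. Compound 3 `CCOc1cccc(-c2ccc(C(=O)N(Cc3cccc(OCCCCCC(=O)O)c3)C(C)C)cc2)c1` has not yet been measured in this assay. Its change from compound 2 is ethoxy in place of 5-methyl-1,3,4-oxadiazol-2-yl on an aromatic carbon, placed meta to a large group on a six-membered aromatic ring of carbon only. Within the data shown here, the only measured step, the one from compound 1 to compound 2, offers no readable size, so there is no measured basis for expecting a step beyond the scatter in either direction. Compound 3 is therefore expected to remain at the same limit, with an estimated value of 30000 nM in this assay, between 12000 nM and 100000 nM. The step this expectation means, a step that the limit leaves unreadable from compound 2 to compound 3, is expected to be none beyond the scatter.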

Compound 3, half-maximal effective concentration: > 20800 nM
Compound 3: no number, only a limit (the forecaster's own chance of this, stated with the estimate: 85%); the middle value does not contradict the limit.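

In this assay compound 3 gives > 20800 nM, which is a limit and not a number. Among these compounds, compound 1, compound 2 and compound 3 all stand at limits, so no step among them can be read in size or direction. The compounds shown leave open what concentration, if any, would give each one a half-maximal effect in this assay.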